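Compound 2 to compound 4: cyclohexyl for 4-methylphenyl

A few compounds are considered here, and "the series" means these few. Any claim that something is new, unique, unknown or untested is made for them only; others in the source may bear on it.

In a functional assay on HeLa cells (Homo sapiens) for cytotoxicity, read by MTT assay, with a stated time of 72 h (on this read-out lower numbers stand for stronger inhibition and higher numbers for weaker inhibition), compound 2 (`Cc1ccc(C(=O)Nc2nnc(-c3ccc(O)c(O)c3)s2)cc1`) gives 67100 nM and lies within the scatter of compound 1 (`O=C(COc1ccccc1)Nc1nnc(-c2cccc(O)c2O)s1`), which gives 117000 nM as its value. Compound 3 (`O=C(Nc1nnc(-c2cccc(O)c2O)s1)c1ccccc1`) gives 21800 nM as the lowest number of the three, beyond the scatter from both.

The change to compound 4 (`O=C(Nc1nnc(-c2ccc(O)c(O)c2)s1)C1CCCCC1`) is cyclohexyl in place of 4-methylphenyl on a carbonyl carbon. Within the data shown here, the one measured step on this carbonyl carbon is a 5.4-fold lower number from compound 1 to compound 3 (0.73 log units; beyond the scatter) and it is modest. That step puts phenyl in place of phenoxymethyl, on the core of compound 3, which is not the core of compound 2. Among the measured compounds shown here, no measured step exchanges an aromatic ring for a non-aromatic one, so the data give no firm direction and the range stays wide.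

The estimated step is a 1.1-fold lower number from compound 2 to compound 4 (0.05 log units; within the scatter) and no change beyond the scatter is expected in this assay on this evidence. For compound 4 the expected value is 60000 nM (estimated range 22000 nM to 150000 nM).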

Compound 4, half-maximal inhibitory concentration: 34500 nM
Compound 4: middle estimate off by 1.7-fold (0.24 log units), on the high side; low and high end bracket the measured number.
By their numbers in this assay, from the lowest: compounds 3, 4, 2 and 1 (each within the scatter of the next, the first and the last beyond it).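

In this assay, a 1.9-fold lower number from compound 2 to compound 4 (0.29 log units; within the scatter), so on the core of compound 2 a non-aromatic six-membered ring of carbon on the carbonyl carbon reads the same as an aromatic one within the scatter. Among these compounds, this is the first measured exchange of an aromatic ring for a non-aromatic one at this position, and the only step at this position on this core; the earlier step from phenoxymethyl to phenyl was on the core of compound 1. No measurement here gives a reason for this result.

From the compounds shown here alone, whether cyclohexyl in place of phenyl behaves the same way on the core of compound 3 remains open. Also open, going by these compounds, is how an amine, a carboxylic acid or a longer chain in place of cyclohexyl on the carbonyl carbon would read in this assay.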